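The source may report more compounds than this note shows. Statements on the series, on what has been measured and on what is new or still open speak of the compounds shown alone.

Compound 1, `Cc1ccc(CO/N=C/c2c(C)nn(C)c2Oc2ccc(Cl)cc2)cc1`, gives 30.4% in a functional assay on MKN-45 cells (Homo sapiens) for antiproliferative activity, tested at 1 uM; on this read-out lower numbers stand for less inhibition and higher numbers for more inhibition at the one concentration tested (going by the name of the read-out). Compound 2, `CCOC(=O)c1ccc(CO/N=C/c2c(C)nn(C)c2Oc2ccc(Cl)cc2)cc1`, gives 20.9%.

Among the compounds with values here, on these two numbers compound 2 stands lowest, but its only neighbour is compound 1, and the change a number 9.5 percentage points lower from compound 1 to compound 2 (within the scatter) lies within the scatter, so the two values cannot be ranked. Compound 3, `COC(=O)c1ccc(CO/N=C/c2c(C)nn(C)c2Oc2ccc(Cl)cc2)cc1`, differs from compound 2 by hydrogen in place of methyl on a saturated chain carbon bound to an oxygen next to a carbonyl group. Within the data shown here, no measured step touches this ethyl-to-methyl change; the only step measured, a number 9.5 percentage points lower from compound 1 to compound 2 (within the scatter), swapped ethoxycarbonyl for methyl and did not move the read-out beyond the scatter. Among the measured compounds shown here, with no relevant step in hand, a shortening of the ester chain by one carbon is expected to leave the read-out in this assay essentially unchanged, so the expected step of a number 1.1 percentage points higher from compound 2 to compound 3 (within the scatter) is none beyond the scatter. Compound 3 is therefore estimated at 22%, with a range from 8% to 36%.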

Compound 3, a percentage reported as inhibition, at one concentration (the size of the read-out at that concentration, not a potency): 26.1%
Estimate against measurement, compound 3: 4.1 percentage points below; measured number inside the range.
By their numbers in this assay, from the lowest: compounds 2, 3 and 1 (each within the scatter of the next).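

Going from ethoxycarbonyl to methoxycarbonyl gives a number 5.2 percentage points higher from compound 2 to compound 3 (within the scatter) in this assay and so cannot be told apart from no change at all. The methyl ester also stays close to the simple methyl group on the same aromatic carbon, with a number 4.3 percentage points lower from compound 1 to compound 3 (within the scatter) as its step, so neither ester now separates from methyl on this read-out. Nothing available offers an explanation for these results.

The compounds shown leave open whether a carboxylic acid, an amide or a longer chain such as butoxycarbonyl on this aromatic carbon would give a number beyond the scatter of these three. They also leave open how these compounds would compare at other concentrations, since a single-concentration percentage is not a measure of potency.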